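The source may report more compounds than this note shows. Statements on the series, on what has been measured and on what is new or still open speak of the compounds shown alone.

Of the compounds shown here, three built on the shared core have been measured in an assay (Cavia porcellus) for inhibition of Polyunsaturated fatty acid 5-lipoxygenase (Homo sapiens); a lower number here means a stronger inhibitor, a higher number a weaker inhibitor. Compound 1 `CC1Oc2ccc(OCc3ccccc3)cc2C=C1CN(O)C(N)=O` gives 220 nM. Compound 2 `CC1Oc2ccc(Oc3ccccc3)cc2C=C1CN(O)C(N)=O` gives 120 nM, and compound 3 `CCCC1Oc2ccc(Oc3ccccc3)cc2C=C1CN(O)C(N)=O` gives 880 nM. Compound 2 has the lowest of the three numbers, but its lead over compound 1 is small: the step of a 1.8-fold lower number from compound 1 to compound 2 (0.26 log units; within the scatter) stays within the scatter. The step of a 7.3-fold higher number from compound 2 to compound 3 (0.87 log units; beyond the scatter), in contrast, lies beyond the scatter.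

The next compound, compound 4 `CC1(C)Oc2ccc(Oc3ccccc3)cc2C=C1CN(O)C(N)=O`, has not yet been measured in this assay. It differs from compound 2 in one place: methyl in place of hydrogen on a saturated ring carbon. Within the data shown here, of the two measured steps, only the one from compound 2 to compound 3 bears on this change, as it also adds carbon at the saturated part of the core, though on the chain rather than on the ring carbon itself. That step was modest and weakening. The present change adds less, and at a different carbon, so a smaller loss is anticipated. The expected step is a 2.5-fold higher number from compound 2 to compound 4 (0.40 log units; beyond the scatter). For compound 4 a somewhat higher number is therefore expected, with an estimated value of 300 nM and a range from 120 nM to 800 nM.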

Compound 4, half-maximal inhibitory concentration: 310 nM
Compound 4: middle estimate off by 1.0-fold (0.01 log units), on the low side; measured number inside the range.
By their numbers in this assay, from the lowest: compounds 2, 1 and 4 (each within the scatter of the next, the first and the last beyond it); then compound 3.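

In this assay the change on the saturated ring carbon next to the ring oxygen gives a 2.6-fold higher number from compound 2 to compound 4 (0.41 log units; beyond the scatter), so this ring carbon itself responds to an added group, and not only the chain carbon bound to it, which was the site of the earlier ethyl step. A methyl, with its 1 heavy atom, is enough to take the step beyond the scatter, and both changes made to compound 2 at this saturated part of the core now point toward a higher number, whereas the exchange of benzyl and phenyl on the oxygen on the aromatic ring stayed within the scatter. No measurement is at hand that would explain this rise.

As far as these compounds go, whether the rise follows any added carbon on this ring carbon or is particular to methyl stays open, and an ethyl group, a fluorine or a hydroxyl in the same place would help to separate those readings. Also open, from the compounds shown here alone, are the effect of hydrogen in place of the remaining methyl on this carbon, and whether the same added methyl would give a similar step in compound 1, with its benzyl on the oxygen.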